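Aryl change from compound 3 to compound 4

A few compounds are considered here, and "the series" means these few. Any claim that something is new, unique, unknown or untested is made for them only; others in the source may bear on it.

In a functional assay on A549 cells (Homo sapiens) for antiproliferative activity, read by MTT assay, with a stated time of 72 h (on this read-out higher numbers stand for weaker inhibition and lower numbers for stronger inhibition), compound 3 `NC1=NC2(CCOCC2)N(OCCCOc2cc(Cl)c(Cl)cc2Cl)C(N)=N1` gives 680 nM, level with compound 1 `COc1ccc(OCCCON2C(N)=NC(N)=NC23CCOCC3)cc1` at 660 nM, while compound 2 `NC1=NC2(CCOCC2)N(OCCCOc2ccc(Cl)cc2Cl)C(N)=N1` gives 70 nM. Compound 4 `NC1=NC2(CCOCC2)N(OCCCOc2cccc(Br)c2)C(N)=N1` carries 3-bromophenyl in place of 2,4,5-trichlorophenyl on an oxygen on a saturated carbon. Among the compounds with values here, three measured steps bear on this. Chloro in place of hydrogen on an aromatic carbon gave a 9.7-fold higher number from compound 2 to compound 3 (0.99 log units; beyond the scatter). The other two aryl swaps gave a 9.4-fold lower number from compound 1 to compound 2 (0.97 log units; beyond the scatter) and a 1.0-fold higher number from compound 1 to compound 3 (0.01 log units; within the scatter). Within the data shown here, no bromo compound has been measured, so only part of the larger steps is carried over, toward lower numbers. The expected step is a 2.3-fold lower number from compound 3 to compound 4 (0.36 log units; beyond the scatter). The estimate for compound 4 is 300 nM, with an expected range of 70 nM to 1200 nM.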

Compound 4, half-maximal inhibitory concentration: 160 nM
Beside the measured number, compound 4's estimate is 1.9-fold (0.27 log units) above it; measured number inside the range.
By their numbers in this assay, from the lowest: compound 2; then compound 4; then compounds 1 and 3 (each within the scatter of the next).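

With 3-bromophenyl at this place, on an oxygen on a saturated carbon, a single halogen is enough for a clear gain over the two weaker aryl groups: a 4.3-fold lower number from compound 3 to compound 4 (0.63 log units; beyond the scatter) and a 4.1-fold lower number from compound 1 to compound 4 (0.62 log units; beyond the scatter). 2,4-Dichlorophenyl still keeps the lead, with a 2.3-fold higher number from compound 2 to compound 4 (0.36 log units; beyond the scatter) as the cost of the swap. Across compound 4, compound 2 and compound 3, the numbers therefore do not follow the halogen count in a single direction. No measurement on hand explains these steps. From the compounds shown here alone, whether an aryl group bearing an amine or a carboxylic acid would hold these numbers remains open.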